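Moving one methyl around a sulfonamide's phenyl group

The compounds below may be only part of what the source reports. "The series", "measured", "known", "first", "only" and "open" are said of these compounds alone.

In a functional assay on K562 cells (Homo sapiens) for inhibition, read by CCK-8 assay, with a stated time of 72 h (on this read-out higher numbers stand for weaker inhibition and lower numbers for stronger inhibition), compound 1 `O=C(/C=C/c1cccnc1)NCCCCCCc1cccc(S(=O)(=O)Nc2ccccc2)c1` gives 0.88 nM as the reference point for this small series. With a 4-methylphenyl on the sulfonamide nitrogen, compound 2 `Cc1ccc(NS(=O)(=O)c2cccc(CCCCCCNC(=O)/C=C/c3cccnc3)c2)cc1` gives 2.98 nM in the same test, which is a 3.4-fold higher number from compound 1 to compound 2 (0.53 log units; beyond the scatter). With a 2-methylphenyl there, compound 3 `Cc1ccccc1NS(=O)(=O)c1cccc(CCCCCCNC(=O)/C=C/c2cccnc2)c1` gives 0.456 nM and thus holds the lowest of the three numbers, although a 1.9-fold lower number from compound 1 to compound 3 (0.29 log units; within the scatter) leaves it level with compound 1. Where the methyl sits can still matter, as a 6.5-fold lower number from compound 2 to compound 3 (0.82 log units; beyond the scatter) shows.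

Compound 4 `Cc1cccc(NS(=O)(=O)c2cccc(CCCCCCNC(=O)/C=C/c3cccnc3)c2)c1` has 3-methylphenyl in place of 2-methylphenyl on a sulfonamide nitrogen. Within the data shown here, no measured compound carries this group, so the two methyl isomers serve only as bounds, and a number between theirs seems most likely. The expected change is a 2.0-fold higher number from compound 3 to compound 4 (0.30 log units; within the scatter), a small rise in the number. For compound 4 the estimated value is 0.9 nM, with an expected range from 0.35 nM to 2.5 nM in this assay once measured.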

Compound 4, half-maximal inhibitory concentration: 4.78 nM
Compound 4: middle estimate off by 5.3-fold (0.73 log units), on the low side, and the stated range ends below it.
By their numbers in this assay, from the lowest: compounds 3 and 1 (each within the scatter of the next); then compounds 2 and 4 (each within the scatter of the next).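

Moving the methyl by one place on the phenyl group of the sulfonamide nitrogen is enough for a large change in this assay: with 3-methylphenyl in place of 2-methylphenyl, the result is a 10-fold higher number from compound 3 to compound 4 (1.02 log units; beyond the scatter). The 3-methylphenyl group stays level with the 4-methylphenyl group (a 1.6-fold higher number from compound 2 to compound 4 (0.21 log units; within the scatter)) and, like it, is clearly worse than no methyl at all (a 5.4-fold higher number from compound 1 to compound 4 (0.73 log units; beyond the scatter)), so of the three methyl isomers only compound 3 stays level with compound 1. No evidence is available on why the isomers differ.

Whether this holds for other groups is open, for instance whether 2-chlorophenyl or 2-methoxyphenyl would match compound 3. It is also unknown whether the same order of isomers would survive a shorter chain in the shared core.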